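A Larger Side Group on a Shared Core

A few compounds are considered here, and "the series" means these few. Any claim that something is new, unique, unknown or untested is made for them only; others in the source may bear on it.

Of the compounds shown here, two have so far been tested in a functional assay on RAW264.7 cells (Mus musculus) for inhibition, read by Griess assay, with stated times of 1 h and 24 h; a higher number here means a weaker inhibitor, a lower number a stronger inhibitor. Compound 1, with the structure `O=C1OC(Cc2nc(-c3ccc(-c4ccccc4)cc3)no2)c2ccccc21`, reaches only a limit in this assay: compound 1 gives > 10000 nM. Compound 2, with the structure `COCCOc1ccc(C(O)C2OC(=O)c3c(OC)cc(OC)cc32)cc1`, likewise reaches only a limit in this assay, and compound 2 gives > 10000 nM. Among the compounds with values here, both measured values sit at the limit of > 10000 nM in this assay, at which 2 of the 2 values shown sit, so nothing more precise than that is known for either, and no numeric step separates compound 2 from compound 1.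

Compound 3, with the structure `COc1cc(OC)c2c(c1)C(C(O)c1ccc(OCc3ccc(OC(F)(F)F)cc3)cc1)OC2=O`, has not yet been tested in this assay. It differs from compound 2 by 4-(trifluoromethoxy)phenyl in place of methoxymethyl on a saturated chain carbon bound to an oxygen on an aromatic ring. Within the data shown here, because the measured compounds give only limits, no measured step tells how large an effect such a change has. Compound 3 is therefore expected to stay close to the same limit, with an expected step of a number no higher from compound 2 to compound 3 (the limit leaves the size open), which is no move beyond the usual scatter. The estimated value for compound 3 in this assay is 10000 nM. The expected range for compound 3 runs from 2000 nM to 30000 nM.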

Compound 3, half-maximal inhibitory concentration: 8140 nM
Estimate against measurement, compound 3: 1.2-fold (0.09 log units) above; low and high end bracket the measured number.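

In this assay compound 3 gives 8140 nM, which makes it the only compound shown with a measured number rather than a limit. Exchanging methoxymethyl for 4-(trifluoromethoxy)phenyl gives an at least 1.2-fold lower number from compound 2 to compound 3 (0.08 log units; that floor lies within the scatter), so this position can carry a much larger group that includes an aromatic ring without the reading being lost beyond the limit of the assay. The true size of the step stays unknown, and even its smallest possible size does not rise above the usual scatter, since compound 2 has only a limit and no number of its own: the limit of > 10000 nM in this assay, at which 2 of the 3 values shown sit.

The compounds shown leave open whether any part of the entering group matters on its own, as a plain phenyl at this place would separate the ring from its trifluoromethoxy group. On these data alone, how this position responds to a different kind of group, such as an amine, a carboxylic acid or a longer chain, also remains open.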